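Chlorine position on the benzylsulfanyl arm in two related pairs

This account rests on a few compounds, and the source may have more. Where it says the series, first, only, none or still open, it means among the compounds named here.

Compound 1 `CC1=C(C(=O)Nc2ccc(F)cc2)C(c2ccc([N+](=O)[O-])cc2)N=C(SCc2cccc(Cl)c2)N1` and compound 2 `CC1=C(C(=O)Nc2ccc(F)cc2)C(c2ccc([N+](=O)[O-])cc2)N=C(SCc2ccc(Cl)cc2)N1` share one core and differ only in 4-chlorophenyl in place of 3-chlorophenyl on a saturated chain carbon bound to a sulfur. In a functional assay on the whole organism (artery, strain albino) with Rattus norvegicus as the target, with a stated time of 720 min, at a dose of 10 mg/kg by the oral route (on this read-out higher numbers stand for more inhibition at the one dose given (going by the name of the read-out) and lower numbers for less inhibition), compound 1 gives 12.9%, while compound 2 gives 22.2%, so that a number 9.3 percentage points higher from compound 1 to compound 2 (within the scatter). Compound 3 `CC1=C(C(=O)Nc2ccc([N+](=O)[O-])cc2)C(c2ccc(Br)cc2)N=C(SCc2cccc(Cl)c2)N1` is built on a second core; the difference between the two cores is not broken down here. In this assay compound 3 gives 2.6%, the lowest of the three numbers. Compound 4 `CC1=C(C(=O)Nc2ccc([N+](=O)[O-])cc2)C(c2ccc(Br)cc2)N=C(SCc2ccc(Cl)cc2)N1` differs from compound 3 by 4-chlorophenyl in place of 3-chlorophenyl on a saturated chain carbon bound to a sulfur, the same change that separates compound 1 from compound 2. Compound 4 is expected to give about 10%, with a range from 0% to 24%. That estimate applies the step of a number 9.3 percentage points higher from compound 1 to compound 2 (within the scatter) to compound 3, which gives 2.6%, and amounts to an expected step of a number 7.4 percentage points higher from compound 3 to compound 4 (within the scatter).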

Compound 4, a percentage reported as inhibition, in the whole organism at one dose (the size of the read-out at that dose, not a potency): 29.4%
Compound 4: the middle estimate sits 19.4 percentage points below what was measured; measured number outside the range, above it.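

In this assay the move from 3-chlorophenyl to 4-chlorophenyl gives a number 26.8 percentage points higher from compound 3 to compound 4 (beyond the scatter) on the second core. The size of this change therefore does not carry over unchanged from one core to the other: the same change on two cores in this assay, a number 9.3 percentage points higher (within the scatter) from compound 1 to compound 2 and a number 26.8 percentage points higher (beyond the scatter) from compound 3 to compound 4, 17.5 percentage points apart, beyond the scatter of two such steps. Among the compounds shown here, with only two pairs, this does not show which of the differences between the cores matters, and it does not establish a shared direction, since the step on the first core lies within the scatter.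

The compounds shown leave open how the two cores would respond if a methoxy group or an amine took the place of chlorine on the benzyl ring. They also leave open whether an unsubstituted benzyl group would fit either trend.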